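Adding a methoxy group to compound 1

The source may hold more compounds than are shown below. What is called first, only, known or untested is meant among the compounds shown, and "the series" means these compounds.

Among the compounds with values here, in an ADME assay on the whole organism (Rattus norvegicus) for pharmacokinetics, at a dose of 2 mg/kg (a higher number here means more compound in the circulation at the dose given, a lower number less compound in the circulation), compound 1 (`Cc1ccc([C@H](C)NC(=O)Cn2nnc3ccccc3c2=O)cc1`) gives 292 nM, the lower of the two numbers available so far. Compound 2 (`COc1cccc2nnn(CC(=O)N[C@@H](C)c3ccc(C)cc3)c(=O)c12`) gives 1540 nM. Compound 3 (`COc1ccc2nnn(CC(=O)N[C@@H](C)c3ccc(C)cc3)c(=O)c2c1`) has not yet been measured. Its structure differs from the core of compound 1 as follows: methoxy in place of hydrogen on an aromatic carbon. Within the data shown here, one measured step bears on this change, and it is also methoxy in place of hydrogen on an aromatic carbon: a 5.3-fold higher number from compound 1 to compound 2 (0.72 log units; beyond the scatter), which lies beyond the scatter. However, compound 2 and compound 3 carry the methoxy at different places on the ring, and a single example sets no rule. A rise in this assay is therefore expected, but a smaller one than that step. The expected size is a 2.2-fold higher number from compound 1 to compound 3 (0.35 log units; beyond the scatter). For compound 3 the estimate is 650 nM, with an expected range from 220 nM to 1900 nM.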

Compound 3, maximal plasma concentration: 42.6 nM
Estimate against measurement, compound 3: 15-fold (1.18 log units) above, outside the stated range (below it).
By their numbers in this assay, from the lowest: compound 3; then compound 1; then compound 2.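

In this assay, methoxy in place of hydrogen on an aromatic carbon, at the place that is meta to a fused ring and para to a fused ring, gives a 6.9-fold lower number from compound 1 to compound 3 (0.84 log units; beyond the scatter), whereas the same group elsewhere on that ring gave a 5.3-fold higher number from compound 1 to compound 2 (0.72 log units; beyond the scatter). The direction of this change therefore depends on where the methoxy sits on the ring, so having the group present does not by itself mean more compound in the circulation. Nothing available here accounts for the opposite outcomes of these two placements.

On these data alone, whether a fluorine atom, a hydroxyl group or an amine at this same place would also give a lower number remains open. So does whether a longer chain, such as ethoxy, would behave as the methoxy does.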